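The compounds below may be only part of what the source reports. "The series", "measured", "known", "first", "only" and "open" are said of these compounds alone.

Among the measured compounds shown here, compound 3 `FC(F)(F)c1ccc(Cn2cncc2-c2cc3cc(Br)ccc3[nH]2)cc1` sits second highest of the three numbers measured so far in an assay on HEK293 cells for inhibition of Indoleamine 2,3-dioxygenase 1 (Homo sapiens), with a stated time of 30 min; a higher number here means that more compound is needed for the effect, a lower number that less compound is needed. Compound 3 gives 4590 nM. Its closest neighbour is compound 2 `Brc1ccc2[nH]c(-c3cncn3Cc3ccc(-c4ccccc4)cc3)cc2c1`, which gives 3090 nM, and the gap between them, a 1.5-fold higher number from compound 2 to compound 3 (0.17 log units; within the scatter), is inside the scatter. The furthest is compound 1 `Brc1ccc2[nH]c(-c3cncn3Cc3ccccc3)cc2c1`, which gives 11000 nM.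

Compound 4 `N#Cc1ccc(Cn2cncc2-c2cc3cc(Br)ccc3[nH]2)cc1` is not yet measured. It differs from compound 3 by one change: cyano in place of trifluoromethyl on an aromatic carbon, on an aromatic carbon of a six-membered aromatic ring of carbon only, para to a large group.

For the measured compounds named here, two measured steps touch the same position. Adding a group at that position gave a 2.4-fold lower number from compound 1 to compound 3 (0.38 log units; beyond the scatter) and a 3.6-fold lower number from compound 1 to compound 2 (0.55 log units; beyond the scatter), both modest improvements. Swapping one such group for another gave only a 1.5-fold higher number from compound 2 to compound 3 (0.17 log units; within the scatter), which is within the scatter. Cyano is a smaller group than trifluoromethyl, so compound 4 may resemble either compound 3 or compound 1; the data give no clear direction.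

Compound 4 is therefore expected to show a 1.1-fold higher number from compound 3 to compound 4 (0.04 log units; within the scatter) in this assay, with nothing beyond the scatter most likely. The estimate for compound 4 is 5000 nM, expected to fall between 2000 nM and 12000 nM.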

Compound 4, half-maximal effective concentration: 6920 nM
Beside the measured number, compound 4's estimate is 1.4-fold (0.14 log units) below it; the range from low to high includes it.
By their numbers in this assay, from the lowest: compounds 2, 3, 4 and 1 (each within the scatter of the next, the first and the last beyond it).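

In this assay, among the compounds shown here, cyano is the first group at this position that cannot be told apart from plain hydrogen: the change gives a 1.6-fold lower number from compound 1 to compound 4 (0.20 log units; within the scatter) and so, unlike trifluoromethyl and phenyl, it has no step from hydrogen beyond the scatter. Cyano also cannot be separated from trifluoromethyl, with a 1.5-fold higher number from compound 3 to compound 4 (0.18 log units; within the scatter) as the step, so compound 4 lies within the scatter of both compound 1 and compound 3 and adds a middle point rather than a clear new level. Only the swap for phenyl gives a difference that can be read, namely a 2.2-fold higher number from compound 2 to compound 4 (0.35 log units; beyond the scatter) and even this is modest, so the three groups tried here separate only weakly at this position.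

The compounds shown leave open how an amine, a carboxylic acid or a longer chain at this position would compare with phenyl, and whether any group here can give more than a modest gain over hydrogen. Nothing available explains why cyano, trifluoromethyl and phenyl fall where they do.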